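Swapping chloro for methyl on the aniline of compound 1

The compounds below may be only part of what the source reports. "The series", "measured", "known", "first", "only" and "open" are said of these compounds alone.

This piece follows one small change made to compound 1, whose structure is `Cc1ccc(Nc2ncc(C(F)(F)F)c(N3Cc4cccc(N(C)S(C)(=O)=O)c4C3)n2)c(Cl)c1`. Its activity was measured in a functional assay on HepG2 cells (Homo sapiens) for antiproliferative activity, read by spectrophotometry, with a stated time of 2 days (on this read-out higher numbers stand for weaker inhibition of growth and lower numbers for stronger inhibition of growth), and there compound 1 gives > 30000 nM, which is a limit of the assay rather than a number. Within the data shown here, that is the only information available for compound 1: it sits at the limit of > 30000 nM in this assay, at which 1 of the 3 values shown sits, so its true potency is not pinned down. Two other compounds sharing the same core but carrying different anilines give real numbers: compound 2, with structure `COc1cc(N2CCN(C(C)=O)CC2)ccc1Nc1ncc(C(F)(F)F)c(N2Cc3cccc(N(C)S(C)(=O)=O)c3C2)n1`, gives 3800 nM in this assay, and compound 3, with structure `CN(c1cccc2c1CN(c1nc(Nc3ccc(Nc4ccccc4)cc3)ncc1C(F)(F)F)C2)S(C)(=O)=O`, gives 8600 nM.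

The new compound, compound 4, has structure `Cc1ccc(Nc2ncc(C(F)(F)F)c(N3Cc4cccc(N(C)S(C)(=O)=O)c4C3)n2)c(C)c1`. It differs from compound 1 only in this: methyl in place of chloro on an aromatic carbon. Among the measured compounds shown here, no measured pair in this set shows what such a swap does, so there is no direct guide. Given that compound 1 gives only a limit, compound 4 is expected to stay weak, with a step from compound 1 estimated as an at least 1.2-fold lower number from compound 1 to compound 4 (0.07 log units; that floor lies within the scatter), that is, no change beyond the usual scatter. Compound 4 is therefore expected to give around 25000 nM, somewhere between 8000 nM and 60000 nM, with a fair chance that only a limit is reported again.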

Compound 4, concentration for 50% growth inhibition: 19100 nM
For compound 4 the middle estimate is 1.3-fold (0.12 log units) above the measured one; the measured number falls inside the stated range.
By their numbers in this assay, from the lowest: compound 2; then compound 3; then compound 4. At a limit, above all of these: compound 1.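

In this assay, among these compounds, compound 1 gives > 30000 nM, which is a limit of the assay and not a number, so the earlier compounds left this aromatic carbon without a measured reading for any group in the 2-chloro-4-methylphenyl series. Compound 4 carries methyl in place of chloro on that carbon, ortho to a large group, and gives 19100 nM, a real number for the 2,4-dimethylphenyl compound. The step is an at least 1.5-fold lower number from compound 1 to compound 4 (0.19 log units; that floor lies within the scatter), and its full size cannot be read because compound 1 holds only a limit: the limit of > 30000 nM in this assay, at which 1 of the 4 values shown sits.

From the compounds shown here alone, whether the swap truly changes growth inhibition stays open, for a floor within the scatter fits both no real change and a much larger one. Also open, going by these compounds, is what a different group on this same aromatic carbon, such as an amine or a carboxylic acid, would do with the rest of compound 4 kept unchanged.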